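The source may report more compounds than this note shows. Statements on the series, on what has been measured and on what is new or still open speak of the compounds shown alone.

Compound 3 `C/C=C/C=C/C(=O)N[C@H](C(=O)NCCCCCCCCCCCCCCCCCC)[C@@H](C)O` carries a long saturated chain on one amide and a dienoyl group on the amine nitrogen. In a functional assay on HepG2 cells (Homo sapiens) for cytotoxicity, read by MTT assay, with a stated time of 48 h (a lower number here means a stronger inhibitor, a higher number a weaker inhibitor), compound 3 gives 284000 nM, the highest of the two numbers recorded. Compound 1 `CCCCCCCCCCCCCCCCCCNC(=O)[C@@H](NC(=O)c1cccs1)[C@@H](C)O` gives 92000 nM in this assay, and a 3.1-fold higher number from compound 1 to compound 3 (0.49 log units; beyond the scatter). Compound 2 `CCCCCCCCCCCCCCCCCCNC(=O)[C@@H](NC(=O)c1cc2ccccc2o1)[C@@H](C)O` gives > 200000 nM in this assay, which is a limit rather than a number. an at least 2.1-fold higher number from compound 1 to compound 2 (0.33 log units; beyond the scatter), while a step that the limit leaves unreadable from compound 2 to compound 3. Compound 4 `CCCCCCCCCCCCCCCCCCNC(=O)[C@@H](NS(=O)(=O)c1ccc(C)cc1)[C@@H](C)O` differs from compound 3 by (4-methylphenyl)sulfonyl in place of (penta-1,3-dien-1-yl)carbonyl on an amine nitrogen. Among the measured compounds shown here, none of the measured steps exchanges a carbonyl for a sulfonyl; each only varies the group on the carbonyl, and those changes shifted the number modestly at most. Compound 4 is therefore expected to stay close to its parent, with a 1.4-fold lower number from compound 3 to compound 4 (0.15 log units; within the scatter) not beyond the scatter, an estimate of 200000 nM ranging from 60000 nM to 600000 nM.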

Compound 4, half-maximal inhibitory concentration: 75800 nM
For compound 4 the middle estimate is 2.6-fold (0.42 log units) above the measured one; the measured number falls inside the stated range.
By their numbers in this assay, from the lowest: compounds 4 and 1 (each within the scatter of the next); then compound 3.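

Exchanging the carbonyl group for a sulfonyl group on this amine nitrogen gives a 3.7-fold lower number from compound 3 to compound 4 (0.57 log units; beyond the scatter), so here the carbonyl itself is replaced, not only the group attached to it. Compared with the thiophen-2-yl amide, the exchange gives a 1.2-fold lower number from compound 1 to compound 4 (0.08 log units; within the scatter), so the sulfonyl compound is not set apart from every carbonyl compound. There is also an at least 2.6-fold lower number from compound 2 to compound 4 (0.42 log units; beyond the scatter), a step that rests on a limit for compound 2: the limit of > 200000 nM in this assay, at which 1 of the 4 values shown sits.

The compounds shown do not separate the part played by the sulfonyl from that of its 4-methylphenyl group. A methylsulfonyl group on the same nitrogen would bear on that question.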